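Terminal chain group swap on the butyrolactone series

The source may report more compounds than this note shows. Statements on the series, on what has been measured and on what is new or still open speak of the compounds shown alone.

Of the compounds shown here, three of the shared core have been measured in a functional assay on K562 cells (Homo sapiens) for antiproliferative activity; a lower number here means a stronger inhibitor of growth, a higher number a weaker inhibitor of growth. Compound 1 `CC(C)(C)C(=O)OCC1(CO)C/C(=C/CCCCCCCCCCCCCCC=O)C(=O)O1` gives 2.58 ug/mL, compound 2 `CCCCCOCCCCCCC/C=C1\CC(CO)(COC(=O)C(C)(C)C)OC1=O` gives 1.15 ug/mL, and compound 3 `COCCCCCCCCCCCCCCC/C=C1/CC(CO)(COC(=O)C(C)(C)C)OC1=O` gives 0.138 ug/mL. Compound 2 thus stands second highest of the three numbers, nearest to compound 1 and furthest from compound 3. Among the measured compounds shown here, the only single-point step measured so far is a 19-fold lower number from compound 1 to compound 3 (1.27 log units; beyond the scatter), which shows that a change at the far end of the chain can move this assay a long way.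

Compound 4 `COC(=O)CCCCCCCCCCCCCC/C=C1\CC(CO)(COC(=O)C(C)(C)C)OC1=O` differs from compound 2 by 7-(methoxycarbonyl)heptyl in place of pentyloxy on a saturated chain carbon, seven bonds along the chain from a double-bonded chain carbon. For the measured compounds named here, no measured step covers this exact change; the step from compound 1 to compound 3 concerns a different pair of terminal groups, so it sets only the scale. Compound 4 carries a carbonyl terminus as compound 1 does, yet a larger group than compound 2, so compound 4 is expected to land between them, giving an estimated 0.8 ug/mL in this assay, within 0.2 ug/mL to 3 ug/mL. The expected step of a 1.4-fold lower number from compound 2 to compound 4 (0.16 log units; within the scatter) is therefore modest and not clearly beyond the scatter.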

Compound 4, concentration for 50% growth inhibition: 0.856 ug/mL
Compound 4: middle estimate off by 1.1-fold (0.03 log units), on the low side; the measured number falls inside the stated range.
By their numbers in this assay, from the lowest: compound 3; then compounds 4 and 2 (each within the scatter of the next); then compound 1.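

In this assay, replacing pentyloxy with 7-(methoxycarbonyl)heptyl on a saturated chain carbon, seven bonds along the chain from a double-bonded chain carbon, gives a 1.3-fold lower number from compound 2 to compound 4 (0.13 log units; within the scatter) and leaves the two compounds indistinguishable. The earlier step, a 19-fold lower number from compound 1 to compound 3 (1.27 log units; beyond the scatter), showed that a terminal change can move the number a long way; this pair shows that a change at the far end of the chain need not, even with 11 heavy atoms entering where 6 leave. Nothing available explains why this change stays within the scatter.

Going by these compounds, whether an amine or a carboxylic acid at the chain end would also stay within the scatter of compound 2 remains open. So does the outcome of a longer chain carrying the same methoxycarbonyl end.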